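The source may hold more compounds than are shown below. What is called first, only, known or untested is meant among the compounds shown, and "the series" means these compounds.

Measured so far in a functional assay on HT-29 cells (Homo sapiens) for cytotoxicity, read by MTT assay, with a stated time of 72 h; on this read-out lower numbers stand for stronger inhibition and higher numbers for weaker inhibition:
- compound 1 `O=C(CN1CCN(c2nnc(Cc3ccccc3)c3ccccc23)CC1)Nc1c(F)cccc1F`: 19700 nM
- compound 2 `O=C(CN1CCN(c2nnc(Cc3ccccc3)c3ccccc23)CC1)Nc1ccc(F)c(F)c1`: 9510 nM

Compound 2 has the lower of the two numbers. For the measured compounds named here, the only measured step, a 2.1-fold lower number from compound 1 to compound 2 (0.32 log units; beyond the scatter), is modest but beyond the scatter.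

Next is compound 3 `Cc1cccc(Cl)c1NC(=O)CN1CCN(c2nnc(Cc3ccccc3)c3ccccc23)CC1`, with the change 2-chloro-6-methylphenyl in place of 3,4-difluorophenyl on an amide-type nitrogen. Going by the values given here, only the one measured step bears on this change, and no compound measured so far carries 2-chloro-6-methylphenyl. The entering name shares its two position numbers with the 2,6-difluorophenyl of compound 1, so the expectation leans towards compound 1 at 19700 nM. This is a thin basis, resting on a single pair. The expected change in this assay is therefore modest, about the size of the measured step but in the opposite direction, towards a higher number. The expected step is a 1.8-fold higher number from compound 2 to compound 3 (0.25 log units; within the scatter). Compound 3 is estimated at 17000 nM, with an expected range of 7000 nM to 40000 nM.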

Compound 3, half-maximal inhibitory concentration: 53600 nM
Compound 3: middle estimate off by 3.2-fold (0.50 log units), on the low side; measured number outside the range, above it.
By their numbers in this assay, from the lowest: compound 2; then compound 1; then compound 3.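

In this assay, 2-chloro-6-methylphenyl in place of 3,4-difluorophenyl on the amide-type nitrogen gives a 5.6-fold higher number from compound 2 to compound 3 (0.75 log units; beyond the scatter) and thereby widens the spread of values at this position well beyond that of the earlier pair. The comparison with 2,6-difluorophenyl gives a 2.7-fold higher number from compound 1 to compound 3 (0.43 log units; beyond the scatter) as the step, so sharing the same position numbers does not make two groups equivalent here, and the identity of the atoms at those positions also matters in this series. No accompanying measurement bears on the origin of these differences.

The compounds shown leave open how much of the rise belongs to the chlorine and how much to the methyl, as neither a 2-chlorophenyl nor a 2-methylphenyl group appears among them, and an unsubstituted phenyl reference is also absent. Equally open, going by these compounds, is whether the position accepts anything other than a halogen- or methyl-bearing phenyl ring, such as a phenyl ring carrying an amine or a carboxylic acid, or a saturated cyclohexyl group on the same nitrogen.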